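Trimming the sugar chain of compound 1

The compounds below may be only part of what the source reports. "The series", "measured", "known", "first", "only" and "open" are said of these compounds alone.

Compound 1 `COc1cc(/C=C/C(=O)N2c3cc(O[C@@H]4O[C@H](CO[C@@H]5O[C@H](CO)[C@@H](O)[C@H](O)[C@H]5O)[C@@H](O)[C@H](O)[C@H]4O)c(O)cc3C[C@H]2C(=O)O)ccc1O` is the starting point. Among the measured compounds shown here, in a physicochemical assay, with a stated time of 30 min (a higher number here means that more compound is needed for the effect, a lower number that less compound is needed), compound 1 gives 40100 nM, the highest of the three numbers measured so far. For the measured compounds named here, compound 2 `COc1cc(/C=C/C(=O)N2c3cc(O[C@@H]4O[C@H](CO[C@@H]5O[C@H](CO)[C@@H](O)[C@H](O)[C@H]5OC(=O)/C=C/c5ccc(O)c(O)c5)[C@@H](O)[C@H](O)[C@H]4O)c(O)cc3C[C@H]2C(=O)O)ccc1O` gives 16100 nM, and the one measured step shows a 2.5-fold lower number from compound 1 to compound 2 (0.40 log units; beyond the scatter). Compound 3 `COc1cc(/C=C/C(=O)O[C@@H]2[C@@H](O)[C@H](Oc3cc4c(cc3O)C[C@@H](C(=O)O)N4C(=O)/C=C/c3ccc(O[C@@H]4O[C@H](CO)[C@@H](O)[C@H](O)[C@H]4O)cc3)O[C@H](CO[C@@H]3O[C@H](CO)[C@@H](O)[C@H](O)[C@H]3O)[C@H]2O)ccc1O` gives 31600 nM, which sits within the scatter of compound 1. Compound 4 `COc1cc(/C=C/C(=O)N2c3cc(O[C@@H]4O[C@H](CO)[C@@H](O)[C@H](O)[C@H]4O)c(O)cc3C[C@H]2C(=O)O)ccc1O` differs from compound 1 in one place: hydrogen in place of 3,4,5-trihydroxy-6-(hydroxymethyl)oxan-2-yl on an oxygen on a saturated carbon. Going by the values given here, no measured step removes a group of this kind; the step from compound 1 to compound 2 adds a group elsewhere and moves the number only modestly, and compounds 1 and 3 show no change. A step within the scatter, a 1.1-fold lower number from compound 1 to compound 4 (0.06 log units; within the scatter), is therefore expected. Compound 4 is estimated at 35000 nM, between 15000 nM and 80000 nM.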

Compound 4, half-maximal effective concentration: 35200 nM
The estimate for compound 4 lay 1.0-fold (0.00 log units) below the measured number, and the stated range covers the measured number.
By their numbers in this assay, from the lowest: compounds 2, 3, 4 and 1 (each within the scatter of the next, the first and the last beyond it).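

In this assay, taking 3,4,5-trihydroxy-6-(hydroxymethyl)oxan-2-yl off an oxygen on a saturated carbon gives a 1.1-fold lower number from compound 1 to compound 4 (0.06 log units; within the scatter). Among the compounds shown here, this is the first measured removal at this position, and it shows that the whole outer sugar can be lost with a step that stays within the scatter. Nothing measured here gives a reason for this result. As far as these compounds go, it remains open how a small group, such as methyl or benzyl, would read on the oxygen freed in compound 4. Whether the remaining sugar of compound 4 can also be removed is open too.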